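Propoxy in Place of Ethyl: A Step Expected Within Scatter

The source may hold more compounds than are shown below. What is called first, only, known or untested is meant among the compounds shown, and "the series" means these compounds.

Of the compounds shown here, two on one shared core have been measured in a functional assay (spleen, spleen) for activation, with Mus musculus as the target; a higher number here means that more compound is needed for the effect, a lower number that less compound is needed. Compound 1, `CCCCNc1nc(N)c2nc(O)n(Cc3ccccc3)c2n1`, gives 1 uM in this assay. Compound 2, `CCc1nc(N)c2nc(O)n(Cc3ccccc3)c2n1`, gives 1 uM in this assay. The single exchange between them, ethyl in place of butylamino on an aromatic carbon, gave no change at the digits printed from compound 1 to compound 2 (within the scatter), so compound 2 stands level with compound 1 at the digits shown. Compound 3, `CCCOc1nc(N)c2nc(O)n(Cc3ccccc3)c2n1`, is not yet measured; it differs from compound 2 by propoxy in place of ethyl on an aromatic carbon. Among the compounds with values here, the only measured step that bears on this exchange at the same aromatic carbon brought no change at the digits printed from compound 1 to compound 2 (within the scatter), a change between a butylamino and an ethyl group that stayed within the scatter. On that ground compound 3 is expected to show a step of no change at the digits printed from compound 2 to compound 3 (within the scatter) in this assay, none beyond the scatter. The estimate for compound 3 in this assay is 1 uM, with a range from 0.3 uM to 3 uM.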

Compound 3, minimum effective concentration: 0.01 uM
The estimate for compound 3 lay 100-fold (2.00 log units) above the measured number; the whole stated range lies above it.
By their numbers in this assay, from the lowest: compound 3; then compounds 1 and 2 (each within the scatter of the next).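

In this assay this aromatic carbon proved far from indifferent to its substituent, although the earlier pair had shown no response there. Propoxy in place of ethyl gave a 100-fold lower number from compound 2 to compound 3 (2.00 log units; beyond the scatter) and propoxy in place of butylamino gave a 100-fold lower number from compound 1 to compound 3 (2.00 log units; beyond the scatter) on the same shared core. Compound 3 thus differs sharply from both earlier compounds, which shows that the flat step between butylamino and ethyl did not hold for every exchange at this position.

As far as these compounds go, whether the step follows the oxygen of the propoxy group, its chain length or the two together stays open, and a methoxy group, a butoxy group or a plain propyl chain at this carbon would bear on that question. No measurement at hand speaks to the cause of the step.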